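The source may hold more compounds than are shown below. What is called first, only, known or untested is meant among the compounds shown, and "the series" means these compounds.

Compound 1 `FC(F)(F)c1ccc(COc2cccc(Nc3ncnc4cc5c(cc34)OCCOCCO5)c2)cc1` gives > 100000 nM in a functional assay on DU-145 cells (Homo sapiens) for antiproliferative activity, read by MTT assay, with a stated time of 72 h; a lower number here means a stronger inhibitor, a higher number a weaker inhibitor; this is a limit of the assay, not a number.
Compound 2 `c1ccc(COc2ccccc2Nc2ncnc3cc4c(cc23)OCCOCCO4)cc1` gives > 100000 nM in this assay; this too is a limit, not a number.
Compound 3 `FC(F)(F)c1ccc(COc2cccc(Nc3ncnc4cc5c(cc34)OCCOCCOCCOCCO5)c2)cc1` gives 26900 nM in this assay.

Compound 2 stands at the limit of the assay (the limit of > 100000 nM in this assay, at which 2 of the 3 values shown sit); its potency is not resolved by the numbers shown, only bounded. Among the compounds with values here, compound 3 is the sole compound with a measured value, and it lies within the range the assay can report.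

Compound 4 `FC(F)(F)c1ccc(COc2ccccc2Nc2ncnc3cc4c(cc23)OCCOCCO4)cc1` differs from compound 2 by a single substitution (trifluoromethyl in place of hydrogen on an aromatic carbon). Within the data shown here, no pair of measured compounds covers this change on its own, so the size of the step is open. Compound 1, which also carries the trifluoromethyl group, sits at the same limit as compound 2, giving no sign that the group on its own brings a compound into the measurable range. Compound 4 is therefore expected to remain near the limit, an estimated step from compound 2 of a number no higher from compound 2 to compound 4 (the limit leaves the size open). The estimate for compound 4 is 100000 nM, within 30000 nM to 300000 nM.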

Compound 4, half-maximal inhibitory concentration: > 100000 nM
Compound 4: no number, only a limit (the forecaster's own chance of this, stated with the estimate: 70%); the middle value lies on the limit itself.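

Within the data shown here, the values of compound 2 and compound 4 are both limits, so no step between them can be read in this assay: the limit of > 100000 nM in this assay, at which 3 of the 4 values shown sit. The compounds shown leave open whether trifluoromethyl in place of hydrogen changes the potency of compound 2 at all, and by how much.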